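Amino in Place of Chloro on the Shared Core

This account rests on a few compounds, and the source may have more. Where it says the series, first, only, none or still open, it means among the compounds named here.

For the measured compounds named here, compound 2 `Nc1nn(C(=O)Nc2ccc(Cc3ccccc3)cc2)c2ccc(Cl)cc12` is the only compound here with a number in a functional assay on SNB-75 cells (Homo sapiens) for antiproliferative activity, read by sulforhodamine B assay, with a stated time of 48 h; a higher number here means that more compound is tolerated, a lower number that less compound is tolerated; it gives 74500 nM. Compound 1 `Nc1nn(C(=O)Nc2ccc(Cc3ccccc3)cc2)c2ccccc12` gives only a limit of this assay, > 100000 nM. The step of an at least 1.3-fold lower number from compound 1 to compound 2 (0.12 log units; that floor lies within the scatter) rests on the limit of > 100000 nM in this assay, at which 1 of the 2 values shown sits, and stays within the scatter. Compound 3 `Nc1ccc2c(c1)c(N)nn2C(=O)Nc1ccc(Cc2ccccc2)cc1` differs from compound 2 by amino in place of chloro on an aromatic carbon. No measured step covers an amino group, and the one step shown is small. For compound 3 the expected step in this assay is a 1.1-fold higher number from compound 2 to compound 3 (0.06 log units; within the scatter), none beyond the scatter. Compound 3 is thus expected to give 85000 nM, between 40000 nM and 200000 nM.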

Compound 3, concentration lethal to 50% of the cells: 57100 nM
Compound 3: middle estimate off by 1.5-fold (0.17 log units), on the high side; low and high end bracket the measured number.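

Amino and chloro at this place on the shared core are not told apart in this assay, as the change gives a 1.3-fold lower number from compound 2 to compound 3 (0.12 log units; within the scatter). Amino in place of hydrogen gives an at least 1.7-fold lower number from compound 1 to compound 3 (0.24 log units; that floor lies within the scatter). That step is only a floor, and it rests on the limit given by compound 1: the limit of > 100000 nM in this assay, at which 1 of the 3 values shown sits.

From the compounds shown here alone, it remains open whether a methoxy group, a carboxylic acid or an acetamide at this place would move the number beyond the scatter. The compounds shown also leave open whether amino in place of chloro would read the same on other cell lines.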